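Amine exchange on the side chain: compound 3 to compound 4

The source may hold more compounds than are shown below. What is called first, only, known or untested is meant among the compounds shown, and "the series" means these compounds.

Values so far in a functional assay on MCF7 cells (Homo sapiens) for antiproliferative activity (on this read-out lower numbers stand for stronger inhibition and higher numbers for weaker inhibition), for the series:
- compound 1 `CC(=O)Oc1ccc(C(=O)Nc2cc3ccc(OCC4CCN(C)C4)c(C)c3oc2=O)cc1CC=C(C)C` gives 1880 nM in this series
- compound 2 `CC(C)=CCc1cc(C(=O)Nc2cc3ccc(OCCC4CCCCN4)c(C)c3oc2=O)ccc1O` gives 710 nM in this series
- compound 3 `CCNCCCOc1ccc2cc(NC(=O)c3ccc(O)c(CC=C(C)C)c3)c(=O)oc2c1C` gives 980 nM in this series
- compound 4 `CC(C)=CCc1cc(C(=O)Nc2cc3ccc(OCCCN(C)C(C)C)c(C)c3oc2=O)ccc1O` has no value yet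

Compound 3, at 980 nM, stands in the middle of the three numbers, within the scatter of both compound 2 and compound 1. The difference on going to compound 4 is isopropyl(methyl)amino in place of ethylamino on a saturated chain carbon, three bonds along the chain from an oxygen on an aromatic ring and the rest of the structure stays the same. For the measured compounds named here, the one measured step that bears on this, a 1.4-fold higher number from compound 2 to compound 3 (0.14 log units; within the scatter), is also an exchange of the amine-bearing group on the chain, and it stays within the scatter. Going by the values given here, compound 1 differs from compound 3 in more than one place and offers no single-change step. Among the compounds with values here, no measured pair carries this exact exchange, so the evidence is thin. No step beyond the scatter is expected in this assay on this basis. The expected change is a 1.1-fold lower number from compound 3 to compound 4 (0.04 log units; within the scatter), which is small. For compound 4 the estimate is 900 nM, with an expected range of 450 nM to 1900 nM in this assay.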

Compound 4, half-maximal inhibitory concentration: 1050 nM
Compound 4: the middle estimate sits 1.2-fold (0.07 log units) below what was measured, and the stated range covers the measured number.
By their numbers in this assay, from the lowest: compounds 2, 3, 4 and 1 (each within the scatter of the next, the first and the last beyond it).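

In this assay, replacing ethylamino with isopropyl(methyl)amino, on a saturated chain carbon three bonds along the chain from an oxygen on an aromatic ring, gives a 1.1-fold higher number from compound 3 to compound 4 (0.03 log units; within the scatter); at this place, a group with 5 heavy atoms and 0 hydrogen-bond donors therefore cannot be told apart from one with 3 heavy atoms and 1 hydrogen-bond donor. The comparison with the ring-bearing side chain points the same way, with a 1.5-fold higher number from compound 2 to compound 4 (0.17 log units; within the scatter) for (isopropyl(methyl)amino)methyl in place of piperidin-2-yl, so compounds 2, 3 and 4 now give three amine variants at this end of the chain with no step beyond the scatter. No available data bear on the cause of this flat response.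

Going by these compounds, whether the response stays flat with a morpholine or a carboxylic acid in place of these amines, or with a longer chain, remains open. Also open, on these data alone, is whether these amine groups would remain indistinguishable in any read-out other than this assay.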